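Thiophene in Place of a Substituted Phenyl Amide

The source may hold more compounds than are shown below. What is called first, only, known or untested is meant among the compounds shown, and "the series" means these compounds.

Compound 1 `O=C(NC(=S)N1CCc2c(OCCCCCOc3ccc(Cl)cc3)cccc21)c1ccc(Br)cc1`: 29100 nM
Compound 2 `O=C(NC(=S)N1CCc2c(OCCCCCOc3ccc(Cl)cc3)cccc21)c1ccc(C(F)(F)F)cc1`: 32700 nM
Compound 3 `CC(C)(C)c1ccc(C(=O)NC(=S)N2CCc3c(OCCCCCOc4ccc(Cl)cc4)cccc32)cc1`: > 50000 nM

In an ADME assay on Huh-7 cells (Homo sapiens) for cytotoxicity (on this read-out lower numbers stand for higher toxicity in this test and higher numbers for lower toxicity in this test), compound 1 gives 29100 nM and compound 2 gives 32700 nM. For compound 3 this assay reports only a limit, > 50000 nM; it sits at the limit of > 50000 nM in this assay, at which 1 of the 3 values shown sits. The measured steps were a 1.1-fold higher number from compound 1 to compound 2 (0.05 log units; within the scatter), an at least 1.7-fold higher number from compound 1 to compound 3 (0.23 log units; that floor lies within the scatter) and an at least 1.5-fold higher number from compound 2 to compound 3 (0.18 log units; that floor lies within the scatter), all within the scatter. Compound 4 `O=C(NC(=S)N1CCc2c(OCCCCCOc3ccc(Cl)cc3)cccc21)c1cccs1` differs from compound 3 by thiophen-2-yl in place of 4-(tert-butyl)phenyl on a carbonyl carbon. The measured steps bear on it only loosely, since each of them exchanged a group on an aromatic carbon rather than the whole ring, and none moved the number beyond the scatter. The expected step is therefore an at least 1.2-fold lower number from compound 3 to compound 4 (0.09 log units; that floor lies within the scatter), no change beyond the scatter. Compound 4 is estimated at 40000 nM, between 18000 nM and 90000 nM.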

Compound 4, half-maximal cytotoxic concentration: 10700 nM
Estimate against measurement, compound 4: 3.7-fold (0.57 log units) above; measured number below the stated range.
By their numbers in this assay, from the lowest: compound 4; then compounds 1 and 2 (each within the scatter of the next). At a limit, above all of these: compound 3.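

Replacing the whole substituted phenyl ring on the carbonyl carbon with thiophen-2-yl does what changing the group on that ring did not: it moves the number beyond the scatter, toward higher toxicity in this test, with a 3.1-fold lower number from compound 2 to compound 4 (0.49 log units; beyond the scatter) and a 2.7-fold lower number from compound 1 to compound 4 (0.43 log units; beyond the scatter). The third step, an at least 4.6-fold lower number from compound 3 to compound 4 (0.66 log units; beyond the scatter), gives only a floor for the size of the change. Compound 3 stands at a limit and not at a measured number: the limit of > 50000 nM in this assay, at which 1 of the 4 values shown sits.

From the compounds shown here alone, whether the drop follows the sulfur, the five-membered ring or the loss of heavy atoms stays open. An unsubstituted phenyl or a furan-2-yl on this carbonyl carbon would help separate these.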